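This account rests on a few compounds, and the source may have more. Where it says the series, first, only, none or still open, it means among the compounds named here.

In a functional assay on the whole organism with Rattus norvegicus as the target, at a dose of 25 mg/kg by the intravenous route (a lower number here means that less compound is needed, a higher number that more compound is needed for the effect), compound 1 `O=C(O)c1cc(NC(=O)c2ccc([N+](=O)[O-])cc2)cc(C(=O)O)c1` gives 9.8 mg/kg. Compound 3 `O=C(Nc1ccc(C(=O)O)c(C(=O)O)c1)c1ccc([N+](=O)[O-])cc1` gives 13.2 mg/kg, within the scatter of compound 1, while compound 2 `O=C(Nc1ccc(-c2nn[nH]n2)cc1)c1cccc(-c2nn[nH]n2)c1` gives 0.05 mg/kg, a much lower number and well beyond the scatter. Compound 4 `N#Cc1ccc(C(=O)Nc2cc(C(=O)O)cc(C(=O)O)c2)cc1` keeps the core of compound 1 but has cyano in place of nitro on an aromatic carbon, para to a large group: cyano in place of nitro on an aromatic carbon. Among the measured compounds shown here, no measured pair shows this exchange, so the expectation in this assay is for no step beyond the scatter and no firm direction. The expected change is a 1.2-fold lower number from compound 1 to compound 4 (0.09 log units; within the scatter). Compound 4 is estimated at 8 mg/kg, with an expected range of 3 mg/kg to 22 mg/kg.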

Compound 4, dose for 50% inhibition: 1.7 mg/kg
Compound 4: the middle estimate sits 4.7-fold (0.67 log units) above what was measured, outside the stated range (below it).
By their numbers in this assay, from the lowest: compound 2; then compound 4; then compounds 1 and 3 (each within the scatter of the next).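

In this assay, placing cyano in place of nitro on an aromatic carbon, para to a large group, gives a 5.8-fold lower number from compound 1 to compound 4 (0.76 log units; beyond the scatter). Among the compounds shown here, this shows that the number responds to the group at this place on the shared core, which the earlier compounds could not show, as no two of them differed only there. No measurement at hand accounts for the size or direction of this step. From the compounds shown here alone, whether chlorine, trifluoromethyl or an amine at this place would give a lower or higher number remains open, as does whether the same exchange on compound 3 would give a similar step.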